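The compounds below may be only part of what the source reports. "The series", "measured", "known", "first", "only" and "open" are said of these compounds alone.

Working notes on the series.

Compound 1 `CC(C)[C@H](NC(=O)c1cc(Cl)ccc1OCCCCNC(=O)OC(C)(C)C)C(=O)Nc1ccc([N+](=O)[O-])cc1Cl` carries a tert-butoxycarbonyl on the chain amine and a nitro-bearing aniline amide. In a functional assay on MDA-MB-231 cells (Homo sapiens) for inhibition, read by MTT assay, with a stated time of 72 h (on this read-out higher numbers stand for weaker inhibition and lower numbers for stronger inhibition), compound 1 reaches only the limit of the measurement, > 10000 nM; this is a limit and not a number, and it is the limit described as the limit of > 10000 nM in this assay, at which 1 of the 3 values shown sits. Compound 2 `CC(C)[C@H](NC(=O)c1cc(Cl)ccc1OCCCCN)C(=O)Nc1ccc([N+](=O)[O-])cc1Cl` is its deprotected counterpart, differing by hydrogen in place of tert-butoxycarbonyl on an amine nitrogen. In this assay compound 2 gives 5590 nM, so the step is an at least 1.7-fold lower number from compound 1 to compound 2 (0.25 log units; that floor lies within the scatter).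

Compound 3 `CC(C)[C@H](NC(=O)c1cc(Cl)ccc1OCCNC(=O)OC(C)(C)C)C(=O)Nc1cc(F)cc(C(F)(F)F)c1` keeps the tert-butoxycarbonyl but on a shorter chain and with a fluoro- and trifluoromethyl-substituted aniline; the difference between its core and that of compound 1 is not broken down here. In this assay compound 3 gives 7870 nM, which sits within the scatter of compound 2.

Compound 4 `CC(C)[C@H](NC(=O)c1cc(Cl)ccc1OCCN)C(=O)Nc1cc(F)cc(C(F)(F)F)c1` is not yet measured. It differs from compound 3 by hydrogen in place of tert-butoxycarbonyl on an amine nitrogen, the same change as from compound 1 to compound 2, and the place is the same word for word, so it is the same change on a different core.

Within the data shown here, the expectation for compound 4 rests on the only measured instance of this change, the step of an at least 1.7-fold lower number from compound 1 to compound 2 (0.25 log units; that floor lies within the scatter) from compound 1, which gives a lower number but with a floor that lies within the scatter; the expected step is therefore a 1.7-fold lower number from compound 3 to compound 4 (0.24 log units; within the scatter), a modest move toward a lower number. In this assay compound 4 is expected to give about 4500 nM, with a likely range from 1800 nM to 11000 nM.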

Compound 4, half-maximal inhibitory concentration: 4340 nM
Beside the measured number, compound 4's estimate is 1.0-fold (0.02 log units) above it; the range from low to high includes it.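

On the second core, hydrogen in place of tert-butoxycarbonyl on an amine nitrogen gives, in this assay, a 1.8-fold lower number from compound 3 to compound 4 (0.26 log units; within the scatter). This shows that the change can be carried to the core of compound 3 without any departure from what the core of compound 1 allows, but neither step is shown to lie beyond the scatter, so a real effect of the change on either core is not established, and neither is a match in size between the two: the same change on two cores in this assay, an at least 1.7-fold lower number (0.25 log units; that floor lies within the scatter) from compound 1 to compound 2 and a 1.8-fold lower number (0.26 log units; within the scatter) from compound 3 to compound 4; the limit leaves it open whether they differ Compound 1 gives > 10000 nM, which is a limit and not a number.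

The compounds shown leave open whether the read-out responds to the free amine itself or only to the loss of tert-butoxycarbonyl, a question that an acetyl or a methyl on the same nitrogen would bear on. The two cores differ in more than one place, in the chain as well as in the aniline substituents, so the contribution of each stays unseparated, and a pair differing in chain length alone, or a longer chain on the fluoro- and trifluoromethyl-substituted aniline, would be needed to tell them apart.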